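Phenethyl in Place of 4-Methylphenyl on Sulfur

The compounds below may be only part of what the source reports. "The series", "measured", "known", "first", "only" and "open" are said of these compounds alone.

Compound 1 `Cc1ccc(SCc2ccc(/C=C/C(=O)Nc3ccccc3N)cc2)cc1` was measured in a functional assay on A549 cells (Homo sapiens) for inhibition, read by CCK-8 assay, with a stated time of 72 h, tested at 2 uM (on this read-out higher numbers stand for more inhibition of growth at the one concentration tested and lower numbers for less inhibition of growth), where compound 1 gives 43.4%. Among the three compounds measured it holds the second highest number: compound 2 `Nc1ccccc1NC(=O)c1ccc(CSc2ccc(Br)cc2)cc1` gives 33.2% and compound 3 `CCc1ccc(SCc2ccc(C(=O)Nc3ccccc3N)cc2)cc1` gives 53.6%, and each of these gaps to compound 1 lies beyond the scatter. Within the data shown here, the only step between two compounds that differ in a single place, a number 20.4 percentage points higher from compound 2 to compound 3 (beyond the scatter), is a change of a group on an aromatic carbon. Compound 4 `Nc1ccccc1NC(=O)/C=C/c1ccc(CSCCc2ccccc2)cc1` differs from compound 1 by phenethyl in place of 4-methylphenyl on a sulfur. Among the measured compounds shown here, no measured step exchanges that ring for a chain, so the step is expected to stay within the scatter, a number 1.4 percentage points lower from compound 1 to compound 4 (within the scatter). Compound 4 is therefore estimated at 42%, with a range from 24% to 60%.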

Compound 4, percent growth inhibition at one concentration: 45.7%
Compound 4: middle estimate off by 3.7 percentage points, on the low side; measured number inside the range.
By their numbers in this assay, from the lowest: compound 2; then compounds 1, 4 and 3 (each within the scatter of the next, the first and the last beyond it).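

Of the compounds shown, only this pair exchanges the whole group on the sulfur, and phenethyl in place of 4-methylphenyl gives a number 2.3 percentage points higher from compound 1 to compound 4 (within the scatter) in this assay. On this one pair, the read-out does not separate an aromatic ring carried on the sulfur through a chain from one sitting on the sulfur itself. Nothing available bears on a cause for this result. Still open, as far as these compounds go, is whether the same place accepts a group without an aromatic ring, such as a plain hexyl chain, or a chain ending in an amine or a carboxylic acid.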